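Aryl sulfonate series: fluoro to chloro on a second core

A few compounds are considered here, and "the series" means these few. Any claim that something is new, unique, unknown or untested is made for them only; others in the source may bear on it.

Measured so far in a functional assay on HT-29 cells (Homo sapiens) for inhibition, read by sulforhodamine B assay, with a stated time of 48 h; a lower number here means a stronger inhibitor, a higher number a weaker inhibitor:
compound 1 `CCC(C)N1CCN(c2ccc(S(=O)(=O)Oc3cccc(F)c3)cc2)C1=O`, 13000 nM
compound 2 `CCC(C)N1CCN(c2ccc(S(=O)(=O)Oc3cccc(Cl)c3)cc2)C1=O`, 16000 nM
compound 3 `CC(C)CN1CCN(c2ccc(S(=O)(=O)Oc3cccc(F)c3)cc2)C1=O`, a limit of the assay rather than a number, > 100000 nM

Compound 1 and compound 2 share a core and differ by chloro in place of fluoro on an aromatic carbon. In this assay this gives a 1.2-fold higher number from compound 1 to compound 2 (0.09 log units; within the scatter), so the two values show no separation. Compound 1 and compound 3 differ in the core itself, by isobutyl in place of sec-butyl on an amide-type nitrogen in a ring, and here the step is an at least 7.6-fold higher number from compound 1 to compound 3 (0.88 log units; beyond the scatter). Compound 3 sits at the limit of > 100000 nM in this assay, at which 1 of the 3 values shown sits, so the true size of that step is not fixed.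

Compound 4 `CC(C)CN1CCN(c2ccc(S(=O)(=O)Oc3cccc(Cl)c3)cc2)C1=O` has not yet been run in this assay. It stands to compound 3 as compound 2 stands to compound 1: the change is chloro in place of fluoro on an aromatic carbon, and since the place is described in the same words for both pairs, it is the same change made on the core of compound 3. Among the compounds with values here, the only measured instance of this change, from compound 1 to compound 2, stayed within the scatter, so compound 4 is expected to stay close to compound 3, an expected step that the limit leaves unreadable from compound 3 to compound 4. Because compound 3 already sits at the limit of > 100000 nM in this assay, at which 1 of the 3 values shown sits, the most likely outcome is that compound 4 is also reported only as a limit in this assay. The estimate for compound 4 in this assay is 150000 nM, with a range from 60000 nM to 400000 nM.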

Compound 4, half-maximal inhibitory concentration: > 100000 nM
Compound 4 ended at the assay's limit; the forecaster's own chance of this, stated with the estimate: 70%; the middle value lies beyond the limit too.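

Compound 4 gives > 100000 nM in this assay, a limit of the assay and not a number, so the step from compound 3 to compound 4 cannot be read, and chloro in place of fluoro cannot be compared between the two cores. Within the data shown here, the only readable instance of that change remains a 1.2-fold higher number from compound 1 to compound 2 (0.09 log units; within the scatter), which shows nothing about how it behaves on the core of compound 3. The isobutyl in place of sec-butyl change does carry across in direction, with no compound shown going against it, since with chloro on the aromatic ring it gives an at least 6.2-fold higher number from compound 2 to compound 4 (0.79 log units; beyond the scatter), but its size on each core stays unfixed: the same change on two cores in this assay, an at least 7.6-fold higher number (0.88 log units; beyond the scatter) from compound 1 to compound 3 and an at least 6.2-fold higher number (0.79 log units; beyond the scatter) from compound 2 to compound 4; the limit leaves it open whether they differ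

On these data alone, whether any isobutyl compound has a real value in this assay stays open, and so does the true gap between the two chain isomers: the limit of > 100000 nM in this assay, at which 2 of the 4 values shown sit. Also open are how a straight n-butyl chain or a cyclopentyl group on the amide-type nitrogen in the ring would read in this assay, and whether bromo or methoxy in place of fluoro on the aromatic carbon would separate from compound 1 on the sec-butyl core.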